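The source may hold more compounds than are shown below. What is called first, only, known or untested is meant among the compounds shown, and "the series" means these compounds.

Compound 1 `O=[N+]([O-])c1cn2c(n1)OC[C@@H](OCc1cn(-c3ccc(C(F)(F)F)cc3)nn1)C2`: > 128000 nM
Compound 2 `N#Cc1ccc(-n2cc(CO[C@@H]3COc4nc([N+](=O)[O-])cn4C3)nn2)cc1`: > 128000 nM

In an ADME assay on Vero cells (Chlorocebus sabaeus) for cytotoxicity, with a stated time of 72 h (a lower number here means a stronger inhibitor, a higher number a weaker inhibitor), compound 2 gives > 128000 nM, which is a limit of the assay rather than a number. Compound 1 gives > 128000 nM in this assay, also a limit. The step that the two limits leave unreadable from compound 1 to compound 2 is thus unreadable, since (the limit of > 128000 nM in this assay, at which 2 of the 2 values shown sit). Compound 3 `O=[N+]([O-])c1cn2c(n1)OC[C@@H](OCc1cn(-c3ccc(F)cc3)nn1)C2` carries fluoro in place of cyano on an aromatic carbon. Among the measured compounds shown here, no measured step gives a readable size for this change, so compound 3 is expected to sit at the limit as well, the step of a number no higher from compound 2 to compound 3 (the limit leaves the size open) being estimated as none beyond the scatter. Compound 3 is therefore estimated at 128000 nM, between 50000 nM and 128000 nM.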

Compound 3, half-maximal inhibitory concentration: > 128000 nM
Compound 3: only a limit was reported (the forecaster's own chance of this, stated with the estimate: 85%); the middle value sits exactly at the limit.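

Among the compounds shown here, compound 3 also reaches a limit in this assay, so no step among compound 1, compound 2 and compound 3 can be read: the limit of > 128000 nM in this assay, at which 3 of the 3 values shown sit. The compounds shown leave open whether trifluoromethyl, cyano and fluoro differ at all in this read-out.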